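The source may report more compounds than this note shows. Statements on the series, on what has been measured and on what is new or still open speak of the compounds shown alone.

Measured compounds in an ADME assay on KB cells (Homo sapiens) for cytotoxicity, read by MTT assay, with a stated time of 44 h; on this read-out higher numbers stand for weaker inhibition and lower numbers for stronger inhibition:

compound 1, `Fc1cccc(F)c1NC(=S)N/N=C\c1c[nH]c2ccccc12` — in this assay compound 1 gives > 100000 nM, which is a limit of the assay.
compound 2, `CC(C)NC(=S)N/N=C\c1c[nH]c2ccccc12` — in this assay compound 2 gives > 100000 nM, which is a limit of the assay.
compound 3, `CCN(CC)C(=S)N/N=C\c1c[nH]c2ccccc12` — in this assay compound 3 gives > 100000 nM, which is a limit of the assay.

Compound 2 therefore stands at the limit of this assay, and no ranking among the three measured compounds is possible. Among the compounds with values here, the one measured step that leaves compound 2, a step that the two limits leave unreadable from compound 2 to compound 3, is unreadable because of the limit of > 100000 nM in this assay, at which 3 of the 3 values shown sit.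

Compound 4, `Cc1ccc(NC(=S)N/N=C\c2c[nH]c3ccccc23)cc1`, differs from compound 2 by 4-methylphenyl in place of isopropyl on an amide-type nitrogen. Within the data shown here, no measured step bears on this change in a readable way: the only step from compound 2 is the unreadable one to compound 3. Compound 1 carries an aryl group on the same nitrogen and sits at its own limit.

With every measured value at the limit, no step beyond the scatter is expected in this assay from this change, and the most likely outcome is another limit. The estimate for compound 4 is 100000 nM, with a range from 30000 nM to 300000 nM. The step of a number no higher from compound 2 to compound 4 (the limit leaves the size open) is expected to be unreadable for the same reason.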

Compound 4, half-maximal inhibitory concentration: > 100000 nM
Compound 4 gave a limit, no number; the forecaster's own chance of this, stated with the estimate: 80%; the middle value sits exactly at the limit.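

The step from compound 2 to compound 4 cannot be read, nor can any other step among compounds 1, 2, 3 and 4 in this assay, because all of them share one limit: the limit of > 100000 nM in this assay, at which 4 of the 4 values shown sit.

The compounds shown leave open whether any group on the amide-type nitrogen of the shared core gives a readable value in this assay.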